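A few compounds are considered here, and "the series" means these few. Any claim that something is new, unique, unknown or untested is made for them only; others in the source may bear on it.

Working notes on the series.

Compound 1 `CN1[C@@H]2c3[nH]c4ccccc4c3C[C@H]1[C@H](C#N)N1[C@@H](CNC(=O)c3cccc(C(F)(F)F)c3)c3[nH]c4ccccc4c3C[C@@H]21` and compound 2 `COc1ccc(C(=O)NC[C@H]2c3[nH]c4ccccc4c3C[C@H]3[C@H]4c5[nH]c6ccccc6c5C[C@@H]([C@H](C#N)N23)N4C)cc1` share one core and differ only in the aryl group on the carbonyl carbon. In a functional assay on HT-29 cells (Homo sapiens) for cytotoxicity, read by MTT assay, with a stated time of 72 h (a higher number here means a weaker inhibitor, a lower number a stronger inhibitor), compound 1 gives 140 nM, while compound 2 gives 840 nM. Among the measured compounds shown here, the single measured step, a 6.0-fold higher number from compound 1 to compound 2 (0.78 log units; beyond the scatter), is the only comparison in hand; compound 2 therefore stands as the highest of the two numbers, with compound 1 the nearest neighbour below it.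

Compound 3 `CN1[C@@H]2c3[nH]c4ccccc4c3C[C@H]1[C@H](C#N)N1[C@@H](CNC(=O)c3ccc(F)cc3)c3[nH]c4ccccc4c3C[C@@H]21` is the next member. Its change from compound 2 is fluoro in place of methoxy on an aromatic carbon; the group leaves and the group enters on an aromatic carbon of a six-membered aromatic ring of carbon only, para to a large group. For the measured compounds named here, no measured step exchanges methoxy for fluoro, so the step from compound 1 to compound 2 bears on it only loosely: it shows that the aryl substituent can move the number in this assay by a modest amount. A change of similar or smaller size is expected, most likely toward a lower number, though a result within the scatter of compound 2 cannot be excluded.

Compound 3 is estimated at 500 nM, within 150 nM to 1600 nM; this estimate means a step of a 1.7-fold lower number from compound 2 to compound 3 (0.23 log units; within the scatter).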

Compound 3, half-maximal inhibitory concentration: 1370 nM
Compound 3: middle estimate off by 2.7-fold (0.44 log units), on the low side; the range from low to high includes it.
By their numbers in this assay, from the lowest: compound 1; then compounds 2 and 3 (each within the scatter of the next).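

Exchanging methoxy for fluoro on an aromatic carbon para to a large group gives a 1.6-fold higher number from compound 2 to compound 3 (0.21 log units; within the scatter) in this assay, so the 4-methoxyphenyl and 4-fluorophenyl groups are not distinguished at this position in this assay. The 3-(trifluoromethyl)phenyl group now stands apart from two different aryl groups rather than one, with a 9.8-fold higher number from compound 1 to compound 3 (0.99 log units; beyond the scatter) alongside a 6.0-fold higher number from compound 1 to compound 2 (0.78 log units; beyond the scatter), both beyond the scatter. No accompanying measurement bears on why these aryl groups read as they do.

As far as these compounds go, the two groups compared with 3-(trifluoromethyl)phenyl both carry their substituent para to a large group, so it remains open whether the identity of the trifluoromethyl group or its place on the ring sets compound 1 apart. A trifluoromethyl group on the aromatic carbon that holds the fluoro in compound 3 would bear on that question, while an amine or a carboxylic acid on the same carbon would show whether the flat reading between methoxy and fluoro extends to substituents of a different kind.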